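A few compounds are considered here, and "the series" means these few. Any claim that something is new, unique, unknown or untested is made for them only; others in the source may bear on it.

Measured so far in an assay on isolated protein with Bile acid receptor (Homo sapiens) as the target; a higher number here means that more compound is needed for the effect, a lower number that less compound is needed:
compound 1 `COC(=O)/C=C/c1cccc(N(Cc2ccc(/C=C/c3ccccn3)cc2)C(=O)C2CCCCC2)c1` — 309 nM
compound 2 `COC(=O)/C=C/c1cccc(N(Cc2ccc(-c3ccc(F)c(F)c3)cc2)C(=O)C2CCCCC2)c1` — 72 nM
compound 3 `COC(=O)/C=C/c1cccc(N(Cc2ccc(-c3ccc(OC)cc3)cc2)C(=O)C2CCCCC2)c1` — 89 nM

Compound 3 stands second highest of the three numbers in this assay. The step of a 1.2-fold higher number from compound 2 to compound 3 (0.09 log units; within the scatter) lies within the scatter, whereas a 3.5-fold lower number from compound 1 to compound 3 (0.54 log units; beyond the scatter) lies beyond it, so compound 3 and compound 2 cannot be ordered against each other on these data.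

Compound 4 `COC(=O)/C=C/c1cccc(N(Cc2ccc(-c3ccc(F)c(Cl)c3)cc2)C(=O)C2CCCCC2)c1` follows from compound 3 by the change (3-chloro-4-fluorophenyl in place of 4-methoxyphenyl on an aromatic carbon). The step that bears on it most directly is a 1.2-fold higher number from compound 2 to compound 3 (0.09 log units; within the scatter): compound 2 carries a 3,4-difluorophenyl group, the closest comparator to the entering 3-chloro-4-fluorophenyl group, and exchanging it for 4-methoxyphenyl moved the number only within the scatter. Likewise a 4.3-fold lower number from compound 1 to compound 2 (0.63 log units; beyond the scatter) and a 3.5-fold lower number from compound 1 to compound 3 (0.54 log units; beyond the scatter) were of comparable size, so the two aryl groups tried so far behaved alike in this assay. For compound 4 the expected step of a 1.3-fold lower number from compound 3 to compound 4 (0.10 log units; within the scatter) is therefore none beyond the scatter, if anything a slightly lower number. The estimate for compound 4 in this assay is 70 nM, with a range from 30 nM to 160 nM.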

Compound 4, half-maximal effective concentration: 66 nM
For compound 4 the middle estimate is 1.1-fold (0.03 log units) above the measured one, within the range that was stated.
By their numbers in this assay, from the lowest: compounds 4, 2 and 3 (each within the scatter of the next); then compound 1.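

In this assay the exchange of 4-methoxyphenyl for 3-chloro-4-fluorophenyl gives a 1.3-fold lower number from compound 3 to compound 4 (0.13 log units; within the scatter) and the exchange of fluoro for chloro gives a 1.1-fold lower number from compound 2 to compound 4 (0.04 log units; within the scatter) within this series. At this aromatic carbon, para to a large group, the loss of the hydrogen-bond acceptor of 4-methoxyphenyl and the entry of chlorine therefore leave no readable mark, while a 4.7-fold lower number from compound 1 to compound 4 (0.67 log units; beyond the scatter) places a third aryl compound clear of the 2-(pyridin-2-yl)ethenyl compound. No measurement on hand accounts for this flat response.

Still open, on these data alone, is whether an aryl group bearing an amine or a carboxylic acid at this position would stay level with compounds 2, 3 and 4. Also open, as far as these compounds go, is whether this flat response would persist with a carboxylic acid in place of the methyl ester.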